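Working notes: piperidin-1-yl replacing dimethylamino on the chain

This account rests on a few compounds, and the source may have more. Where it says the series, first, only, none or still open, it means among the compounds named here.

In a functional assay on SK-BR-3 cells (Homo sapiens) for antiproliferative activity, read by MTT assay, with a stated time of 72 h (on this read-out higher numbers stand for weaker inhibition and lower numbers for stronger inhibition), compound 1 `CCN1CCN(c2cc(C)c3cc(NC(=O)c4cccc(Cl)c4)ccc3n2)CC1` gives 17800 nM, compound 3 `CCN1CCN(c2cc(C)c3cc(NC(=O)c4cccc(F)c4)ccc3n2)CC1` gives 24900 nM, and compound 2 `Cc1cc(NCCN(C)C)nc2ccc(NC(=O)c3ccc(Cl)c(Cl)c3)cc12` gives 6670 nM. The only one-place step among these, a 1.4-fold higher number from compound 1 to compound 3 (0.15 log units; within the scatter), stays within the scatter. Compound 2 stands lowest of the three numbers; compound 1 and compound 3 both read higher by margins beyond the scatter, so compound 2 is the most potent of the measured set. Compound 4 `Cc1cc(NCCN2CCCCC2)nc2ccc(NC(=O)c3ccc(Cl)c(Cl)c3)cc12` differs from compound 2 by piperidin-1-yl in place of dimethylamino on a saturated chain carbon, two bonds along the chain from a nitrogen on an aromatic ring. Within the data shown here, no measured step touches this part of the molecule; the one step at hand swaps halogens on an aromatic carbon and bears little on the chain amine. The change is therefore expected to give a step within the scatter, a 1.1-fold lower number from compound 2 to compound 4 (0.05 log units; within the scatter), with no settled direction. Compound 4 is estimated at 6000 nM, range 2500 nM to 15000 nM.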

Compound 4, half-maximal inhibitory concentration in the SK-BR-3 assay: 1800 nM
Beside the measured number, compound 4's estimate is 3.3-fold (0.52 log units) above it; measured number below the stated range.
By their numbers in the SK-BR-3 assay, from the lowest: compound 4; then compound 2; then compounds 1 and 3 (each within the scatter of the next).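

In the SK-BR-3 assay the chain amine proves to be a position that responds, which the halogen step on the aromatic carbon could not show: a 3.7-fold lower number from compound 2 to compound 4 (0.57 log units; beyond the scatter). In a physicochemical assay for lipophilicity, at pH 7.4 (on this read-out lower numbers stand for lower lipophilicity and higher numbers for higher lipophilicity), compound 2 gives 1.47 and compound 4 gives 2.72. The stronger inhibition comes with higher lipophilicity, though this single pair cannot separate lipophilicity from the ring itself: the measured distribution coefficient of compound 2, 1.47, and of compound 4, 2.72, a number 1.25 log units higher (beyond the scatter)

Going by these compounds, whether the gain is specific to piperidin-1-yl remains open. A morpholin-4-yl or pyrrolidin-1-yl group on the same chain would help to settle that.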